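Chloro on the Benzoate of a Lactone Ester

This account rests on a few compounds, and the source may have more. Where it says the series, first, only, none or still open, it means among the compounds named here.

Compound 2 has the structure `CC1(C)COC(=O)[C@@H]1OC(=O)c1ccccc1`. In an assay on isolated protein for inhibition of fatty acid synthase (Mus musculus), read by spectrophotometry, using NADPH, with stated times of 30 min and 3 min, in the presence of a further agent that is not named here (on this read-out lower numbers stand for stronger inhibition and higher numbers for weaker inhibition), compound 2 gives 23000 nM. Its companion is compound 1, `CC(=O)O[C@H]1C(=O)OCC1(C)C`, which in this assay gives 33200 nM; the two numbers lie within the scatter of each other, so neither compound can be called more potent than the other on this evidence. The change that follows leads to compound 3, `CC1(C)COC(=O)[C@@H]1OC(=O)c1ccc(Cl)cc1`. It differs from compound 2 by chloro in place of hydrogen on an aromatic carbon. Among the compounds with values here, no pair of measured compounds with such a change exists here, so there is no measured step to lean on. Given how little the two measured numbers differ, the step is estimated as a 1.5-fold lower number from compound 2 to compound 3 (0.19 log units; within the scatter). Compound 3 is therefore expected to give about 15000 nM in this assay, with a likely range from 5000 nM to 45000 nM.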

Compound 3, half-maximal inhibitory concentration: 19200 nM
Beside the measured number, compound 3's estimate is 1.3-fold (0.11 log units) below it; low and high end bracket the measured number.
By their numbers in this assay, from the lowest: compounds 3, 2 and 1 (each within the scatter of the next).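

In this assay, within the data shown here, chloro in place of hydrogen on an aromatic carbon, para to a large group, gives a 1.2-fold lower number from compound 2 to compound 3 (0.08 log units; within the scatter) and is the first step here between two compounds that differ in only one place. At this position of the benzoate ring, then, one added chlorine atom leaves the number indistinguishable from that of compound 2. Nothing measured here explains this result.

A single substituent at a single position cannot show whether this place on the ring is generally insensitive to change, so an amine, a carboxylic acid or a longer chain there might or might not give a step beyond the scatter. From the compounds shown here alone, whether chloro on another carbon of the ring would give a similar number also remains open.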